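This account rests on a few compounds, and the source may have more. Where it says the series, first, only, none or still open, it means among the compounds named here.

Compound 1 `COc1ccc(/C=N/c2c(C#N)ncn2-c2ccc(F)cc2)cc1` and compound 2 `CC(C)c1ccc(/C=N/c2c(C#N)ncn2-c2ccc(F)cc2)cc1` share one core, and compound 3 `COc1ccc(C2N=C(C(N)=O)c3ncn(-c4ccc(F)cc4)c3N2)cc1` and compound 4 `CC(C)c1ccc(C2N=C(C(N)=O)c3ncn(-c4ccc(F)cc4)c3N2)cc1` share another; how the two cores differ is not broken down here. In a functional assay on MCF7 cells (Homo sapiens) for antiproliferative activity, read by MTT assay, with a stated time of 48 h (on this read-out higher numbers stand for weaker inhibition and lower numbers for stronger inhibition), compound 1 gives 9330 nM and compound 2 gives 9870 nM. The change between them is isopropyl in place of methoxy on an aromatic carbon and it made a 1.1-fold higher number from compound 1 to compound 2 (0.02 log units; within the scatter), a step within the scatter. In this assay compound 3 gives 3990 nM, the lowest of the three numbers, with the nearest, compound 1, beyond the scatter above it.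

The change from compound 3 to compound 4 is isopropyl in place of methoxy on an aromatic carbon, the same change as from compound 1 to compound 2, made on the other core. Since that change moved the number only within the scatter from compound 1 to compound 2, compound 4 is expected to stay close to compound 3 in this assay, with an expected step of a 1.1-fold higher number from compound 3 to compound 4 (0.03 log units; within the scatter). Compound 4 is therefore estimated at 4300 nM, expected to lie between 2000 nM and 9500 nM.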

Compound 4, half-maximal inhibitory concentration: 3460 nM
For compound 4 the middle estimate is 1.2-fold (0.09 log units) above the measured one, and the stated range covers the measured number.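

In this assay, the swap from 4-methoxyphenyl to 4-isopropylphenyl on the second core gave a 1.2-fold lower number from compound 3 to compound 4 (0.06 log units; within the scatter), so on this core too the step stays inside the scatter. Set side by side, the two steps agree: the same change on two cores in this assay, a 1.1-fold higher number (0.02 log units; within the scatter) from compound 1 to compound 2 and a 1.2-fold lower number (0.06 log units; within the scatter) from compound 3 to compound 4, 1.2-fold (0.09 log units) apart, within the scatter of two such steps. This shows that a change which did little on one core also did little on the other in this assay, but with both steps this small it does not show whether a change with a larger effect would carry over between the cores, and two pairs establish no general rule for the series.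

The compounds shown leave open how other groups at this place on the six-membered aromatic ring, such as an amine, a carboxylic acid or a longer chain, would read on either core. Going by these compounds, all four numbers come from this assay, and how these pairs would behave in any other assay also remains open.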